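One Measured Anilino Compound and a Bromo-Methyl Cousin

This account rests on a few compounds, and the source may have more. Where it says the series, first, only, none or still open, it means among the compounds named here.

Compound 1, `Cc1n[nH]c2ccc(-c3nc4cnc(N5CCN(C)CC5)cn4c3Nc3cccc(Cl)c3)cc12`: "not determined" (no result reported) in a functional assay on MV4-11 cells (Homo sapiens) for inhibition, with a stated time of 120 h; a higher number here means a weaker inhibitor, a lower number a stronger inhibitor 
Compound 2, `Cc1n[nH]c2ccc(-c3nc4cnc(N5CCN(C)CC5)cn4c3Nc3ccc(Cl)cc3)cc12`: 3510 nM in this assay 
Compound 3, `COc1ccc(Nc2c(-c3ccc4[nH]nc(C)c4c3)nc3cnc(N4CCN(C)CC4)cn23)cc1`: "not determined" (no result reported) in this assay 

All of these compounds share one core and differ only in the group on a nitrogen on an aromatic ring. Compound 2 stands alone with a number: of the three measured entries it is the only one for which this assay gave a result, compound 1 and compound 3 having none. Compound 4, `Cc1cc(Br)ccc1Nc1c(-c2ccc3[nH]nc(C)c3c2)nc2cnc(N3CCN(C)CC3)cn12`, is not yet measured. Its difference from compound 2 is 4-bromo-2-methylphenyl in place of 4-chlorophenyl on a nitrogen on an aromatic ring. Going by the values given here, no step between two measured compounds is available, so the size of such a change cannot be read from any neighbouring pair. One halogen takes the place of another and a methyl joins the ring; such a change is expected to move the number little, in either direction, not beyond the usual scatter. Compound 4 is therefore estimated at 3000 nM, within 800 nM to 12000 nM. The expected step from compound 2 to compound 4 is a 1.2-fold lower number from compound 2 to compound 4 (0.07 log units; within the scatter), no more than the usual variation.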

Compound 4, half-maximal inhibitory concentration: 10900 nM
Compound 4: the middle estimate sits 3.6-fold (0.56 log units) below what was measured, within the range that was stated.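

Going by these compounds alone, this is the first step that can be read at this position: in this assay, putting 4-bromo-2-methylphenyl in place of 4-chlorophenyl gives a 3.1-fold higher number from compound 2 to compound 4 (0.49 log units; beyond the scatter), so the aromatic group on this nitrogen does affect inhibition, and this change weakens it modestly. Two things change at once, a bromine replacing a chlorine and a methyl joining the ring, so this single step cannot show which of them accounts for the loss, or whether both contribute. No measurement available here explains the loss.

Within the data shown here, compounds 1 and 3 have no result, so no step involving either can be read. Going by these compounds, how the bromine alone, the methyl alone, or an amine or a carboxylic acid on this ring would behave remains open.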